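The source may hold more compounds than are shown below. What is called first, only, known or untested is meant among the compounds shown, and "the series" means these compounds.

Compound 1 `O=C(O)[C@H](CO)NC(=O)[C@H]1C[C@H](O)CN1`: > 12 h
Compound 2 `O=C(O)[C@H](CO)NC(=O)[C@H]1C[C@@H](O)CN1`: > 12 h
Compound 3 `O=C(N[C@H](CO)C(=O)O)[C@@H]1C[C@@H](O)CN1`: > 12 h

All three entries are limits, not numbers, in an ADME assay on Caco-2 cells (Homo sapiens) for metabolic stability, read by HPLC, with a stated time of 12 h; on this read-out lower numbers stand for a shorter-lived compound and higher numbers for a longer-lived compound. From the compounds shown here alone, compound 3 stands at the limit of > 12 h, so its true position is unknown. Compound 4 `O=C(O)[C@H](CO)NC(=O)[C@@H]1C[C@@H](O)CN1` is related to it by the two compounds have the same atoms and bonds and differ only in configuration as drawn: 1 of 3 stereo elements differ; a stereocentre at a saturated chain carbon is drawn R in compound 3 and S in compound 4. Only the saturated chain carbon changes, drawn R in compound 3 and S in compound 4.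

Three measured steps also change configuration alone: a step that the two limits leave unreadable from compound 1 to compound 2, a step that the two limits leave unreadable from compound 1 to compound 3 and a step that the two limits leave unreadable from compound 2 to compound 3. None has a readable size, yet all three compounds share (the limit of > 12 h in this assay, at which 3 of the 3 values shown sit). No step beyond the scatter, in either direction, is therefore expected in this assay. The estimate is a step that the limit leaves unreadable from compound 3 to compound 4. For compound 4, the expected half-life is 15 h, with an estimated range of 8 h to 30 h.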

Compound 4, half-life: > 12 h
Compound 4 gave a limit, no number; the forecaster's own chance of this, stated with the estimate: 85%; the middle value lies beyond the limit too.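

Among these compounds, compound 4, like compounds 1, 2 and 3, gives only a limit in this assay, so no step among them can be read. The compounds shown leave open how far each half-life lies past that limit and whether configuration alters it.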